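Indole in Place of Phenoxy on a Crown Ether Ester

The compounds below may be only part of what the source reports. "The series", "measured", "known", "first", "only" and "open" are said of these compounds alone.

Compound 1 `O=C(CCCCOc1ccccc1)OCC1COCCOCCOCCOCCOCCO1` carries a phenoxymethyl group on a saturated chain ester. In a functional assay on WiDr cells (Homo sapiens) for inhibition, read by sulforhodamine B assay, with a stated time of 48 h (on this read-out higher numbers stand for weaker inhibition of growth and lower numbers for stronger inhibition of growth), compound 1 reports > 100000 nM, which is a limit of the assay, as recorded in the limit of > 100000 nM in this assay, at which 1 of the 2 values shown sits. Compound 2 `O=C(OCC1COCCOCCOCCOCCOCCO1)c1cccc(-c2ccc(Br)cc2)c1` gives 6200 nM in this assay. Compound 3 `O=C(CCCc1cc2ccccc2[nH]1)OCC1COCCOCCOCCOCCOCCO1` has not been measured; it differs from compound 1 in one place: 1H-indol-2-yl in place of phenoxymethyl on a saturated chain carbon, three bonds along the chain from a carbonyl carbon. Among the measured compounds shown here, only a limit is known for compound 1, and no measured step of this kind exists. A move toward stronger inhibition of growth, beyond the scatter, is expected, an at least 2.0-fold lower number from compound 1 to compound 3 (0.30 log units; that floor lies within the scatter). Compound 3 is expected to give about 50000 nM, between 8000 nM and 200000 nM.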

Compound 3, concentration for 50% growth inhibition: > 100000 nM
Compound 3 gave a limit, no number; the forecaster's own chance of this, stated with the estimate: 45%; middle value at least 2.0-fold (0.30 log units) away from the limit.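

Compound 1 and compound 3 both sit at a limit in this assay, so no step between them can be read: the limit of > 100000 nM in this assay, at which 2 of the 3 values shown sit.

Going by these compounds, whether 1H-indol-2-yl in place of phenoxymethyl changes growth inhibition at all remains open.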